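Chloro on the pendant phenyl: from compound 2 to compound 3

The compounds below may be only part of what the source reports. "The series", "measured", "known", "first", "only" and "open" are said of these compounds alone.

Two compounds of the shared core have been run so far. Compound 1 `O=C(CSc1nc(-c2ccccc2)c(C(=O)O)c(=O)[nH]1)Nn1c(COc2ccc(Cl)cc2Cl)nc2ccccc2c1=O` gives 64.9% in a functional assay on the whole organism (strain albino) for inhibition, with Rattus norvegicus as the target, read by paw edema, with stated times of 1 h and 3 h, at a dose of 100 mg/kg by the oral route; on this read-out lower numbers stand for a weaker effect and higher numbers for a stronger effect at the one dose given. Compound 2 `N#Cc1c(Cl)nc(SCC(=O)Nn2c(COc3ccc(Cl)cc3Cl)nc3ccccc3c2=O)nc1-c1ccccc1` gives 68.4% in this assay, the higher of the two numbers, but its gap to compound 1 lies within the scatter, so the two read as alike. Compound 3 `N#Cc1c(Cl)nc(SCC(=O)Nn2c(COc3ccc(Cl)cc3Cl)nc3ccccc3c2=O)nc1-c1ccc(Cl)cc1` differs from compound 2 by chloro in place of hydrogen on an aromatic carbon. Among the measured compounds shown here, no measured pair isolates this change, so the step in this assay is expected to stay small, at a number 0.6 percentage points higher from compound 2 to compound 3 (within the scatter). For compound 3 the expected read-out is 69%, in a range from 55% to 80%.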

Compound 3, a percentage reported as inhibition, in the whole organism at one dose (the size of the read-out at that dose, not a potency): 68.4%
Estimate against measurement, compound 3: 0.6 percentage points above; measured number inside the range.
By their numbers in this assay, from the lowest: compounds 1, 2 and 3 (each within the scatter of the next).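

Phenyl to 4-chlorophenyl is the first change in the series confined to one place, and in this assay it reads as no change at the digits printed from compound 2 to compound 3 (within the scatter). A chlorine on this aromatic carbon is therefore tolerated at the one dose given, though this single read-out is no measure of potency. No measurement here bears on why the read-out holds.

Still open, as far as these compounds go, is whether an amine or a methoxy group at the same place on the ring would move the read-out. From the compounds shown here alone, the effect of a carboxylic acid in place of the nitrile on the chloro-substituted compound also remains open.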